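Adding a Second Chloro Group: Expected Cytotoxicity

The compounds below may be only part of what the source reports. "The series", "measured", "known", "first", "only" and "open" are said of these compounds alone.

Compound 1 `Cc1ccccc1C(=O)NO`: in an ADME assay on Huh-7 cells (Homo sapiens) for cytotoxicity, read by MTT assay, with a stated time of 72 h (on this read-out lower numbers stand for higher toxicity in this test and higher numbers for lower toxicity in this test), compound 1 gives 650000 nM.
Compound 2 `O=C(NO)c1ccccc1Cl`: in this assay compound 2 gives 330000 nM.
Compound 3 `COCc1ccccc1C(=O)NO`: in this assay compound 3 reaches only the assay limit > 1000000 nM.

Compound 2 sits at the low end of the numbers shown, although the step of a 2.0-fold lower number from compound 1 to compound 2 (0.29 log units; within the scatter) lies within the scatter of repeated measurements. The limit for compound 3 is described by the limit of > 1000000 nM in this assay, at which 1 of the 3 values shown sits, so it counts as a boundary rather than a number.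

Compound 4 `O=C(NO)c1ccc(Cl)cc1Cl` differs from compound 2 by a single change: chloro in place of hydrogen on an aromatic carbon. Among the measured compounds shown here, two measured steps touch a chloro group on the same ring. The step of a 2.0-fold lower number from compound 1 to compound 2 (0.29 log units; within the scatter) exchanged a methyl for chloro and stayed within the scatter. The step of an at least 3.0-fold higher number from compound 2 to compound 3 (0.48 log units; beyond the scatter) removed the chloro in favour of methoxymethyl and moved beyond it. Neither step adds a second chloro, so the evidence is indirect. A second chloro is therefore expected to shift this assay only modestly, if at all, in the downward direction, and the step of a 1.7-fold lower number from compound 2 to compound 4 (0.22 log units; within the scatter) is an estimate rather than a measurement. Compound 4 is expected to give about 200000 nM, with a range from 70000 nM to 600000 nM.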

Compound 4, half-maximal cytotoxic concentration: 140000 nM
Beside the measured number, compound 4's estimate is 1.4-fold (0.15 log units) above it; the measured number falls inside the stated range.
By their numbers in this assay, from the lowest: compound 4; then compounds 2 and 1 (each within the scatter of the next). At a limit, above all of these: compound 3.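

The new position is an open ring carbon, para to a hydroxycarbamoyl group and meta to a chloro group, whereas the earlier ring steps only exchanged one group for another at the place that already carried the methyl, chloro or methoxymethyl group. In this assay, among the compounds shown here, filling this position with chloro gives a 2.4-fold lower number from compound 2 to compound 4 (0.37 log units; beyond the scatter), the first downward step in this set that lies beyond the scatter, so a lower number here means higher toxicity in this test. The change therefore shows that this ring position can affect the read-out on its own, even though the first chloro group stays in place, and nothing measured here gives a cause for the shift.

From the compounds shown here alone, what remains open is whether this step belongs to chloro itself or would also appear with another group at this position, such as an amine, a carboxylic acid or a longer chain. Going by these compounds, it is also open whether the same chloro would give a similar step on the core of compound 1 or compound 3, where the neighbouring group on the ring is methyl or methoxymethyl rather than chloro.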